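This account rests on a few compounds, and the source may have more. Where it says the series, first, only, none or still open, it means among the compounds named here.

In an assay on isolated protein for inhibition of endoplasmic reticulum aminopeptidase 1 (Homo sapiens), with stated times of 15 min and 20 min (on this read-out lower numbers stand for stronger inhibition and higher numbers for weaker inhibition), compound 1, `CC(C)(NC(=O)c1cc(F)cc2cc(-c3ccc(Cl)cc3)oc12)c1nnn[nH]1`, gives 275 nM. Compound 2, `CC(C)(NC(=O)c1cc(F)cc2cc(-c3ccc(Cl)cc3)oc12)C(N)=O`, carries a carbamoyl group where compound 1 carries a tetrazole ring; in this assay compound 2 reaches only the limit of > 10000 nM, which is a boundary of the measurement rather than a number. This is the weakest point among the three measured values, and the change from compound 1 to compound 2 gives an at least 36-fold higher number from compound 1 to compound 2 (1.56 log units; beyond the scatter). Compound 3, `CN(C(=O)c1cc(F)cc2cc(-c3ccc(Cl)cc3)oc12)C(C)(C)C(=O)O`, carries a carboxylic acid in place of the carbamoyl group and a methyl on the amide-type nitrogen; in this assay compound 3 gives 1970 nM, and the step gives an at least 5.0-fold lower number from compound 2 to compound 3 (0.70 log units; beyond the scatter).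

Compound 4, `O=C(NC1(C(=O)O)CCCCC1)c1cc(F)cc2cc(-c3ccc(Cl)cc3)oc12`, is not yet measured. Compared with compound 2 the change is 1-carboxycyclohexyl in place of 1-carbamoyl-1-methylethyl on an amide-type nitrogen. The acid is kept as in compound 3, while the two methyls are closed into a ring and the amide-type nitrogen keeps its hydrogen as in compound 1. The measured steps that bear on this are the loss from compound 1 to compound 2 and the recovery from compound 2 to compound 3, both beyond the scatter, so a clear move toward stronger inhibition is expected. Compound 4 is therefore estimated at 1000 nM, between 300 nM and 4000 nM, an expected step of an at least 10-fold lower number from compound 2 to compound 4 (1.00 log units; beyond the scatter).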

Compound 4, half-maximal inhibitory concentration: 34 nM
Compound 4: the middle estimate sits 29-fold (1.47 log units) above what was measured; measured number below the stated range.
By their numbers in this assay, from the lowest: compound 4; then compound 1; then compound 3. At a limit, above all of these: compound 2.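

A carboxylic acid at this position need not fall behind the tetrazole: compound 3 had suggested it would, with a 7.2-fold higher number from compound 1 to compound 3 (0.86 log units; beyond the scatter), yet the 1-carboxycyclohexyl group of compound 4, with the amide hydrogen in place, gives an 8.1-fold lower number from compound 1 to compound 4 (0.91 log units; beyond the scatter). Set against the carbamoyl group of compound 2, the same 1-carboxycyclohexyl group gives an at least 290-fold lower number from compound 2 to compound 4 (2.46 log units; beyond the scatter), so this substituent on the amide-type nitrogen can shift the read-out far more than the earlier steps had shown. That step has only a minimum size, as compound 2 is known only as a limit of the measurement: the limit of > 10000 nM in this assay, at which 1 of the 4 values shown sits.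

Compound 4 differs from compound 1 in both the acid and the ring, and from compound 3 in both the ring and the amide hydrogen. The compounds shown do not tell these features apart. A cyclohexane ring carrying the tetrazole, a cyclopentane ring carrying the carboxylic acid, or an amine in place of the acid lies outside the compounds shown, and how any of them would read in this assay remains unknown.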